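A few compounds are considered here, and "the series" means these few. Any claim that something is new, unique, unknown or untested is made for them only; others in the source may bear on it.

Series on the shared core of compound 1 `COc1ccc(-c2cc(-c3ccc(C(F)(F)F)cc3)cnc2N)cn1`. In a physicochemical assay for solubility, read by nephelometry, in phosphate buffer, measured as kinetic solubility, at pH 6.5 (a higher number here means a more soluble compound, a lower number a less soluble compound), compound 1 gives 1.6 ug/mL. For the measured compounds named here, compound 2 `COc1ccc(-c2cc(-c3ccc(-n4cccn4)cc3)cnc2N)cn1` gives 3.1 ug/mL in this assay; the only measured step, a 1.9-fold higher number from compound 1 to compound 2 (0.29 log units; within the scatter), leaves the two values within the scatter of each other. Compound 3 `COc1ccc(-c2cc(-c3ccc(C(=O)O)cc3)cnc2N)cn1` differs from compound 2 by carboxy in place of 1H-pyrazol-1-yl on an aromatic carbon. Going by the values given here, no measured step exchanges the group at this position for a carboxy, so the one recorded step bears only loosely on it. For compound 3 a rise in this assay is expected, a 9.7-fold higher number from compound 2 to compound 3 (0.99 log units; beyond the scatter), larger than the recorded step. Compound 3 is estimated at 30 ug/mL, with a range from 5 ug/mL to 150 ug/mL.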

Compound 3, solubility: 6.3 ug/mL
For compound 3 the middle estimate is 4.8-fold (0.68 log units) above the measured one, within the range that was stated.
By their numbers in this assay, from the lowest: compounds 1 and 2 (each within the scatter of the next); then compound 3.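

For the compounds shown here, at this position, on an aromatic carbon para to a large group, carboxy gives the first steps that clear the scatter in (this assay): (a 2.0-fold higher number from compound 2 to compound 3 (0.31 log units; beyond the scatter)) and (a 3.9-fold higher number from compound 1 to compound 3 (0.60 log units; beyond the scatter)), both modest. The earlier exchange of 1H-pyrazol-1-yl for trifluoromethyl separated nothing here, so a difference at this position now shows only with carboxy. No evidence on hand explains these steps. On these data alone, whether an amine or a primary amide at this position would match carboxy remains open, as does whether carboxy gives the same rise elsewhere on the shared core.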